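Methoxy in place of chloro on a pyrazoline aryl group

This account rests on a few compounds, and the source may have more. Where it says the series, first, only, none or still open, it means among the compounds named here.

Compound 2 `Clc1ccc(C2=NN(c3ccc(-c4ccccc4)nn3)C(c3ccc(Cl)cc3)C2)cc1` was tested in a functional assay on HepG2 cells (Homo sapiens) for antiproliferative activity, read by MTT assay, with a stated time of 24 h (a lower number here means a stronger inhibitor, a higher number a weaker inhibitor), and gave 10000 nM, the highest of the two numbers recorded so far. Its nearest neighbour is compound 1 `Clc1ccc(C2CC(c3ccccc3)=NN2c2ccc(-c3ccccc3)nn2)cc1`, which in this assay gave 6310 nM; the step from compound 1 to compound 2 is a 1.6-fold higher number from compound 1 to compound 2 (0.20 log units; within the scatter), so the two compounds cannot be told apart on these data. The structural change toward compound 3 `COc1ccc(C2CC(c3ccc(Cl)cc3)=NN2c2ccc(-c3ccccc3)nn2)cc1` is methoxy in place of chloro on an aromatic carbon. Within the data shown here, the only measured step concerns the same position: putting chloro on that aromatic carbon moved the number by a 1.6-fold higher number from compound 1 to compound 2 (0.20 log units; within the scatter), which gives no sign that this position is sensitive. Among the measured compounds shown here, no measured pair shows what methoxy does at any position, so the expectation rests on that single step alone. Compound 3 is therefore expected to land close to compound 2, with a step of about a 1.3-fold lower number from compound 2 to compound 3 (0.10 log units; within the scatter) in this assay that is not expected to exceed the scatter. The estimate for compound 3 in this assay is 8000 nM, with a likely range from 3000 nM to 20000 nM.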

Compound 3, half-maximal inhibitory concentration: > 100000 nM
Compound 3 was reported as a limit; the forecaster's own chance of this, stated with the estimate: 25%; middle value at least 12-fold (1.09 log units) from the limit.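

In this assay, among these compounds, the change from 4-chlorophenyl to 4-methoxyphenyl gives an at least 10-fold higher number from compound 2 to compound 3 (1.00 log units; beyond the scatter), the first step in this set that lies beyond the scatter. The earlier step, a 1.6-fold higher number from compound 1 to compound 2 (0.20 log units; within the scatter), left this 4-chlorophenyl group untouched, so it could not speak to this position; the new step shows that the position, on a six-membered aromatic ring of carbon only and para to a large group, does respond to a change of substituent. Compound 3 is reported only as a limit of the assay, so the step gives a lower bound on the size of the change and no exact size: the limit of > 100000 nM in this assay, at which 1 of the 3 values shown sits.

The compounds shown leave open whether the chloro itself is what matters here or whether methoxy is what does harm, since only these two groups are seen at this position. A compound with hydrogen, fluoro, methyl, hydroxyl or an amine in the same place would separate those readings, and methoxy on the other aryl group of the shared core would show whether the effect is confined to this position.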